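Compound 2 to compound 3: benzamido exchanged

This account rests on a few compounds, and the source may have more. Where it says the series, first, only, none or still open, it means among the compounds named here.

In an ADME assay on cells (Hepatocyte, Mus musculus) for metabolic stability, with a stated time of 30 min (a higher number here means that more of the compound is left, a lower number that less of the compound is left), compound 1 `CS(=O)(=O)NC1CCC(CN2CCN(c3cc(=O)c4cc(C(F)(F)F)cc([N+](=O)[O-])c4s3)CC2)CC1` gives 111% and compound 2 `O=C(NC1CCC(CN2CCN(c3cc(=O)c4cc(C(F)(F)F)cc([N+](=O)[O-])c4s3)CC2)CC1)c1ccccc1` gives 90.6%, the lower of the two numbers and the starting point here. Compound 3 `O=C(OC1CCC(CN2CCN(c3cc(=O)c4cc(C(F)(F)F)cc([N+](=O)[O-])c4s3)CC2)CC1)c1ccncc1` has not yet been measured. It carries ((pyridin-4-yl)carbonyl)oxy in place of benzamido on a saturated ring carbon.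

Going by the values given here, only one measured step bears on this change: a number 20.4 percentage points lower from compound 1 to compound 2 (beyond the scatter), a modest step beyond the scatter, with benzoyl in place of methylsulfonyl on an amine nitrogen. That step keeps the amine nitrogen and offers only a rough guide to size. Among the compounds with values here, no measurement yet isolates the loss of that nitrogen or the arrival of an aromatic ring with a hetero atom. A step of similar or somewhat larger size is therefore expected in this assay, more likely downward, though the data do not settle the direction. The expected step is a number 20.6 percentage points lower from compound 2 to compound 3 (beyond the scatter). For compound 3 the estimated value is 70%, with an expected range from 40% to 100%.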

Compound 3, percent of the compound remaining: 1.4%
Compound 3: the middle estimate sits 68.6 percentage points above what was measured; measured number outside the range, below it.
By their numbers in this assay, from the lowest: compound 3; then compound 2; then compound 1.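

In this assay the group on this saturated ring carbon can decide almost the whole read-out, with compound 3 at 1.4%. The exchange of benzamido for ((pyridin-4-yl)carbonyl)oxy gives a number 89.2 percentage points lower from compound 2 to compound 3 (beyond the scatter) and the exchange of methanesulfonamido for the same group gives a number 109.6 percentage points lower from compound 1 to compound 3 (beyond the scatter), both large, whereas the step that keeps the amine nitrogen, a number 20.4 percentage points lower from compound 1 to compound 2 (beyond the scatter), is modest. The high numbers of the two compounds with that nitrogen therefore do not carry over to the ((pyridin-4-yl)carbonyl)oxy group, which also has 0 hydrogen-bond donors where benzamido has 1. Nothing available here explains the fall in the read-out.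

This exchange alters the atom attached to the ring carbon and the aromatic ring together, so the compounds shown leave open which of the two accounts for the step. Going by these compounds alone, a benzoyloxy group or a (pyridin-4-yl)carbonylamino group on the same ring carbon would separate the two, since each carries only one of these changes.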